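The compounds below may be only part of what the source reports. "The series", "measured", "known", "first", "only" and "open" are said of these compounds alone.

Four compounds share one core and differ only in the group hanging from one end of it. Compound 1 `C=C[C@@](C)(/C=C/c1ccc(Nc2ccc(Cl)cc2)cc1)CCC=C(C)C` carries a (4-chlorophenyl)amino group there, compound 2 `C=C[C@@](C)(/C=C/c1ccc(Nc2ccc(Cl)c(Cl)c2)cc1)CCC=C(C)C` a (3,4-dichlorophenyl)amino group, compound 3 `C=C[C@@](C)(/C=C/c1ccc(-c2ccc(Cl)cc2)cc1)CCC=C(C)C` a 4-chlorophenyl group, and compound 4 `C=C[C@@](C)(/C=C/c1ccc(-c2ccc(Cl)c(Cl)c2)cc1)CCC=C(C)C`, not yet measured, a 3,4-dichlorophenyl group.

The three measured compounds were tested in a functional assay on HepG2 cells (Homo sapiens) for cytotoxicity, with a stated time of 72 h; a higher number here means that more compound is needed for the effect, a lower number that less compound is needed. In this assay compound 1 reaches only the limit of the assay, > 52000 nM. In this assay compound 2 likewise gives only a limit, > 52000 nM. In this assay compound 3 also stops at a limit, > 52000 nM. Limits are not numbers, so the steps between these compounds cannot be read: a step that the two limits leave unreadable from compound 1 to compound 2, a step that the two limits leave unreadable from compound 1 to compound 3 and a step that the two limits leave unreadable from compound 2 to compound 3. What the data do show is the limit of > 52000 nM in this assay, at which 3 of the 3 values shown sit.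

The change from compound 1 to compound 2 is chloro in place of hydrogen on an aromatic carbon. The change from compound 3 to compound 4 is chloro in place of hydrogen on an aromatic carbon. Both happen in the same place and are the same change. The two cores they sit on differ as follows: 4-chlorophenyl in place of (4-chlorophenyl)amino on an aromatic carbon.

For compound 4 the step that the limit leaves unreadable from compound 3 to compound 4 is expected to remain unreadable. This rests on compound 3 giving > 52000 nM and on the earlier step that the two limits leave unreadable from compound 1 to compound 2, which the limits left unreadable. Compound 4 is therefore estimated at 90000 nM, between 40000 nM and 300000 nM, most likely reported once more only as a limit.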

Compound 4, half-maximal effective concentration: > 52000 nM
Compound 4: no number, only a limit; the forecaster's own chance of this, stated with the estimate: 85%; the middle value does not contradict the limit.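

In this assay compound 4 gives only a limit of > 52000 nM and not a number. The steps linking compound 4 to compound 1, compound 2 and compound 3 therefore cannot be read, and all four compounds end at the same point: the limit of > 52000 nM in this assay, at which 4 of the 4 values shown sit. The compounds shown leave open whether any of them has a measurable effect on these cells, and so how their end groups compare.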